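The compounds below may be only part of what the source reports. "The series", "measured", "known", "first", "only" and "open" are said of these compounds alone.

Compound 3 `COc1ccc2c(OCC[C@@H]3NC(=O)N(C)CCCC/C=C\[C@@H]4C[C@@]4(C(=O)NS(=O)(=O)N4CCOCC4)NC3=O)cc(-c3nc(C(C)C)cs3)nc2c1Cl` gives 26400 nM in an ADME assay on cells (Homo sapiens) for activation (a lower number here means that less compound is tolerated, a higher number that more compound is tolerated), the lowest of the two numbers shown; compound 1 `COc1ccc2c(OCC[C@@H]3NC(=O)N(C)CCCC/C=C\[C@@H]4C[C@@]4(C(=O)NS(=O)(=O)C4(F)CC4)NC3=O)cc(-c3nc(C(C)C)cs3)nc2c1Cl` gives 51400 nM, and that gap is a 1.9-fold lower number from compound 1 to compound 3 (0.29 log units; within the scatter). Compound 2 `COc1ccc2c(OCC[C@@H]3NC(=O)N(C)CCCC/C=C\[C@@H]4C[C@@]4(C(=O)NS(=O)(=O)C4(C#N)CC4)NC3=O)cc(-c3nc(C(C)C)cs3)nc2c1Cl` reports only a limit, > 75000 nM, in this assay. Compound 4 `COc1ccc2c(OCC[C@@H]3NC(=O)N(C)CCCC/C=C\[C@@H]4C[C@@]4(C(=O)NS(=O)(=O)N4CCC[C@H]4C#N)NC3=O)cc(-c3nc(C(C)C)cs3)nc2c1Cl` follows from compound 3 by one change: 2-cyanopyrrolidin-1-yl in place of morpholin-4-yl on a sulfonyl sulfur. Going by the values given here, the steps that bear on it are a 1.9-fold lower number from compound 1 to compound 3 (0.29 log units; within the scatter) and an at least 2.8-fold lower number from compound 2 to compound 3 (0.45 log units; beyond the scatter), in which the morpholine replaced a cyclopropyl group on the same sulfur; the new ring reverses that direction and carries a nitrile, for which an at least 1.4-fold higher number from compound 1 to compound 2 (0.16 log units; that floor lies within the scatter) is the only guide, noting (the limit of > 75000 nM in this assay, at which 1 of the 3 values shown sits). A modest rise in the tolerated number is therefore expected, a 1.6-fold higher number from compound 3 to compound 4 (0.20 log units; within the scatter). Compound 4 is estimated at 42000 nM, between 18000 nM and 90000 nM.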

Compound 4, half-maximal cytotoxic concentration: 28300 nM
Compound 4: middle estimate off by 1.5-fold (0.17 log units), on the high side; measured number inside the range.
By their numbers in this assay, from the lowest: compounds 3, 4 and 1 (each within the scatter of the next). At a limit, above all of these: compound 2.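

In this assay, the 2-cyanopyrrolidin-1-yl group on the sulfonyl sulfur cannot be told from the morpholin-4-yl group: a 1.1-fold higher number from compound 3 to compound 4 (0.03 log units; within the scatter). Nor does the new ring separate from the 1-fluorocyclopropyl group: a 1.8-fold lower number from compound 1 to compound 4 (0.26 log units; within the scatter). A nitrile on the group is thus not enough to match the 1-cyanocyclopropyl group, whose number is only a limit: an at least 2.6-fold lower number from compound 2 to compound 4 (0.42 log units; beyond the scatter).

Open, as far as these compounds go, is what a plain pyrrolidin-1-yl group or the opposite stereocentre would give on this sulfur, and so what the nitrile itself contributes. Also open, from the compounds shown here alone, is where the true number for the 1-cyanocyclopropyl group lies.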